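This account rests on a few compounds, and the source may have more. Where it says the series, first, only, none or still open, it means among the compounds named here.

Compound 1 `CN1CCc2nc(C#Cc3ccccc3)sc2C1` is the only one of these compounds with a measurable number in an assay on HEK293 cells for positive allosteric modulation of metabotropic glutamate receptor 5 (Homo sapiens), read by FLIPR, with a stated time of 1 h; on this read-out lower numbers stand for an effect already at smaller amounts and higher numbers for an effect only at larger amounts of compound: compound 1 gives 34 nM. Compound 2 `CC(C)CN1CCc2nc(C#Cc3ccccc3)sc2C1` reaches only a limit of the assay, giving > 10000 nM. Compound 3 `O=C(C1CCC1)N1CCc2nc(C#Cc3ccccc3)sc2C1` also sits at a limit, with > 10000 nM; it therefore stands at the limit of > 10000 nM in this assay, at which 2 of the 3 values shown sit, and no real number for it is known. Compound 4 `O=C(CC1CCOCC1)N1CCc2nc(C#Cc3ccccc3)sc2C1` has not yet been measured and differs from compound 3 by (oxan-4-yl)methyl in place of cyclobutyl on a carbonyl carbon. The relevant measured steps are an at least 290-fold higher number from compound 1 to compound 3 (2.46 log units; beyond the scatter) and a step that the two limits leave unreadable from compound 2 to compound 3. Because compound 3 stands at a limit > 10000 nM, compound 4, which keeps a carbonyl on the ring nitrogen, is expected to show a step that the limit leaves unreadable from compound 3 to compound 4, that is, to stay at the limit. The estimate for compound 4 is 20000 nM, with a range from 5000 nM to 100000 nM.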

Compound 4, half-maximal effective concentration: 470 nM
For compound 4 the middle estimate is 43-fold (1.63 log units) above the measured one; measured number outside the range, below it.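

On a carbonyl carbon bound to an amide-type nitrogen in a ring, the group carried by that carbonyl decides the outcome: (oxan-4-yl)methyl in place of cyclobutyl gives an at least 21-fold lower number from compound 3 to compound 4 (1.32 log units; beyond the scatter). A carbonyl at this place therefore does not by itself hold a compound at the limit, and compound 4 leaves the values that sit there: the limit of > 10000 nM in this assay, at which 2 of the 4 values shown sit.

The change adds both a ring oxygen and a larger group, and the compounds shown do not separate the two. A cyclohexylmethyl group or a plain oxan-4-yl group on the same carbonyl would help to tell them apart.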